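Adding chloro to the phenyl of compound 3

A few compounds are considered here, and "the series" means these few. Any claim that something is new, unique, unknown or untested is made for them only; others in the source may bear on it.

Measured so far in a functional assay on SK-OV-3 cells (Homo sapiens) for antiproliferative activity, read by MTT assay, with a stated time of 72 h; on this read-out lower numbers stand for stronger inhibition and higher numbers for weaker inhibition
- compound 1 `O=C(CCc1cccc2c1B(O)OC2)Nc1cccc(Br)c1` gives 540 nM
- compound 2 `C#Cc1cccc(NC(=O)CCc2cccc3c2B(O)OC3)c1` gives 980 nM
- compound 3 `O=C(CCc1cccc2c1B(O)OC2)Nc1cccc(-c2ccccc2)c1` gives 250 nM

Compound 3 has the lowest number of the three at 250 nM, and its steps to both others lie beyond the scatter. The next structure is compound 4 (`O=C(CCc1cccc2c1B(O)OC2)Nc1cccc(-c2cccc(Cl)c2)c1`). The change is chloro in place of hydrogen on an aromatic carbon, which turns phenyl into 3-chlorophenyl.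

Within the data shown here, two measured steps bear on this most closely, and both install the phenyl that is now being substituted: a 2.2-fold lower number from compound 1 to compound 3 (0.33 log units; beyond the scatter) and a 3.9-fold lower number from compound 2 to compound 3 (0.59 log units; beyond the scatter). Both are modest, while a 1.8-fold higher number from compound 1 to compound 2 (0.26 log units; within the scatter) stays within the scatter. None of these steps adds a group to the phenyl itself, so the series holds no direct measure of this change. No step beyond the scatter is expected in this assay, with only a slight lean towards a lower number. The expected step is a 1.3-fold lower number from compound 3 to compound 4 (0.10 log units; within the scatter). Compound 4 is estimated at 200 nM, with an expected range of 80 nM to 500 nM.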

Compound 4, half-maximal inhibitory concentration: 300 nM
Compound 4: the middle estimate sits 1.5-fold (0.18 log units) below what was measured, and the stated range covers the measured number.
By their numbers in this assay, from the lowest: compounds 3, 4, 1 and 2 (each within the scatter of the next, the first and the last beyond it).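

In this assay, among these compounds, chloro in place of hydrogen on the phenyl of compound 3 gives a 1.2-fold higher number from compound 3 to compound 4 (0.08 log units; within the scatter) and so leaves the number unchanged within the scatter, the first reading of a change on this phenyl rather than of a swap of the whole group. The 3-chlorophenyl in place of ethynyl still gives a 3.3-fold lower number from compound 2 to compound 4 (0.51 log units; beyond the scatter) while the 3-chlorophenyl in place of bromo gives a 1.8-fold lower number from compound 1 to compound 4 (0.26 log units; within the scatter) so the separation from compound 1 that phenyl showed beyond the scatter does not carry over to the chlorinated group. Nothing at hand explains this result.

Open, from the compounds shown here alone, is whether an amine or a carboxylic acid on this phenyl would give a step beyond the scatter. Also open, going by these compounds, is how chloro behaves on the other carbons of the same ring.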